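Working notes on cytotoxicity across four related compounds

The source may hold more compounds than are shown below. What is called first, only, known or untested is meant among the compounds shown, and "the series" means these compounds.

Compound 1 `Cc1ccc(NC(=O)CSc2snnc2-c2ccc(Cl)cc2Cl)c(Br)c1`, compound 2 `Cc1ccc(NC(=O)CSc2snnc2-c2ccc(F)cc2F)c(Br)c1` and compound 3 `O=C(CSc1snnc1-c1ccc(F)cc1F)Nc1ccccc1[N+](=O)[O-]` have been measured in an ADME assay on MT4 cells (Homo sapiens) for cytotoxicity; a lower number here means that less compound is tolerated, a higher number that more compound is tolerated. For compound 1 the assay reports only a limit, > 255000 nM. For compound 2 the assay again reports only a limit, > 273000 nM. Compound 3 gives 165000 nM in this assay. The change 2,4-dichlorophenyl in place of 2,4-difluorophenyl on an aromatic carbon gives a step that the two limits leave unreadable from compound 2 to compound 1. The two cores differ by 2-nitrophenyl in place of 2-bromo-4-methylphenyl on an amide-type nitrogen, which gives an at least 1.6-fold lower number from compound 2 to compound 3 (0.21 log units; that floor lies within the scatter). Compound 4 `O=C(CSc1snnc1-c1ccc(Cl)cc1Cl)Nc1ccccc1[N+](=O)[O-]` is not yet measured; it differs from compound 3 by 2,4-dichlorophenyl in place of 2,4-difluorophenyl on an aromatic carbon, the same change, at the same place, as that made from compound 2 to compound 1. For compound 4 the expected step is a 1.0-fold higher number from compound 3 to compound 4 (0.01 log units; within the scatter), which rests on the step that the two limits leave unreadable from compound 2 to compound 1, left unreadable by the two limits. Compound 4 is estimated at 170000 nM, expected to fall between 80000 nM and 320000 nM.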

Compound 4, half-maximal cytotoxic concentration: > 283000 nM
Compound 4 ended at the assay's limit; the forecaster's own chance of this, stated with the estimate: 35%; middle value at least 1.6-fold (0.22 log units) from the limit.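

In this assay, 2,4-dichlorophenyl in place of 2,4-difluorophenyl on the core of compound 3 gives an at least 1.7-fold higher number from compound 3 to compound 4 (0.23 log units; that floor lies within the scatter). Compound 4 reaches only a limit of the assay, and the step is therefore a floor and not a measured size: the limit of > 283000 nM in this assay, at which 1 of the 4 values shown sits. The steps between two limits cannot be read, including that of the same change from compound 2 to compound 1, and the series therefore does not show whether the change carries from one core to the other.

From the compounds shown here alone, the actual values of the compounds at a limit remain open. Also open, going by these compounds, is how this assay responds when an amine or a carboxylic acid replaces the nitro group of the 2-nitrophenyl.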